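Adding a Second Hydroxyl to the Side Chain of Compound 1

This account rests on a few compounds, and the source may have more. Where it says the series, first, only, none or still open, it means among the compounds named here.

Of the compounds shown here, three built on one shared core have been tested in a functional assay on MCF7 cells (Homo sapiens) for antiproliferative activity, read by MTT assay, with a stated time of 48 h, tested at 25 uM; on this read-out higher numbers stand for a weaker effect at the one concentration tested and lower numbers for a stronger effect. Compound 1 `C[C@@H](O)CCn1nc2c(Br)c(Br)c(Br)c(Br)c2n1` gives 77%, the lowest of the three numbers and so the strongest effect among them. Compound 2 `OC(CCn1nc2c(Br)c(Br)c(Br)c(Br)c2n1)c1ccc(Br)cc1` gives 105%, and compound 3 `OC(CCn1nc2c(Br)c(Br)c(Br)c(Br)c2n1)c1ccc(Cl)cc1` gives 92%. Among the measured compounds shown here, the only single-point step between measured compounds is a number 13 percentage points lower from compound 2 to compound 3 (beyond the scatter), a change of the halogen on an aromatic carbon far from the chain that carries the hydroxyl.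

Compound 4 `OCC(O)Cn1nc2c(Br)c(Br)c(Br)c(Br)c2n1` has not been measured. Compared with compound 1, the change is 1,2-dihydroxyethyl in place of 2-hydroxypropyl on a saturated chain carbon bound to an aromatic nitrogen. For the measured compounds named here, no measured pair shows what a second hydroxyl on this chain does; the step from compound 2 to compound 3 touches a different part of the molecule and gives no guidance here. With nothing pointing either way, the expectation is a step from compound 1 of a number 5 percentage points higher from compound 1 to compound 4 (within the scatter), which is no more than the usual scatter of this measurement. On that basis compound 4 is estimated at 82%, with a plausible range from 62% to 102%, the width of the range reflecting how little the measured compounds say about this particular change.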

Compound 4, a percentage reported as activity, at one concentration (the size of the read-out at that concentration, not a potency): 111%
The estimate for compound 4 lay 29 percentage points below the measured number; the measured number lies above the stated range.
By their numbers in this assay, from the lowest: compound 1; then compound 3; then compounds 2 and 4 (each within the scatter of the next).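

In this assay the chain on the shared core proves sensitive to a small edit: the step is a number 34 percentage points higher from compound 1 to compound 4 (beyond the scatter) and it is large, so 1,2-dihydroxyethyl in place of 2-hydroxypropyl leaves a clearly weaker effect at the one concentration tested. Both groups hold 4 heavy atoms, so this is not a matter of adding bulk by that count; a carbon gives way to an oxygen, a second hydroxyl appears, and the defined stereocentre of the leaving group is gone. Among the compounds shown here, nothing measured here explains why this swap moves the number so far.

The compounds shown leave open whether the weaker effect follows the second hydroxyl itself, the loss of the carbon it replaces, or the loss of the defined stereocentre of compound 1, since all of these arrive together in this one step. They also leave open how this place on the chain would respond to an amine, a carboxylic acid, or a longer chain carrying a single hydroxyl, such as 3-hydroxybutyl.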